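One Ring Swap in a PC-9 Cell Inhibition Series

The compounds below may be only part of what the source reports. "The series", "measured", "known", "first", "only" and "open" are said of these compounds alone.

Measured so far:
- compound 1, `CCc1cccc(Nc2cc(NC(=O)Nc3cc(OC)cc(OC)c3)ncn2)c1`: 82.1%
- compound 2, `COc1ccc(C(F)(F)F)cc1Nc1cc(NC(=O)Nc2c(Cl)cccc2Cl)ncn1`: 89%

Both compounds were tested in a functional assay on PC-9 cells (Homo sapiens) for inhibition, read by MTT assay, with a stated time of 48 h, tested at 10 uM; on this read-out lower numbers stand for less inhibition and higher numbers for more inhibition at the one concentration tested (going by the name of the read-out). Compound 1 gives 82.1%, the lower of the two numbers, while compound 2 gives 89%; the gap between them lies within the usual scatter, so the two cannot be ranked against each other.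

The untested compound 3, `COc1cc(NC(=O)Nc2cc(Nc3cc(F)ccc3OC)ncn2)cc(OC)c1`, differs from compound 1 in one place:
5-fluoro-2-methoxyphenyl in place of 3-ethylphenyl on a nitrogen on an aromatic ring

Among the measured compounds shown here, no pair of measured compounds that differ in exactly one place is available, so the size of this step cannot be read from data. Because compound 1 sits at 82.1% and compound 2 at 89%, both high, compound 3 is expected to stay in the same region, with the step of a number 2.1 percentage points lower from compound 1 to compound 3 (within the scatter) expected to be small and not beyond the scatter. Compound 3 is therefore estimated at 80%, within 65% to 92%.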

Compound 3, a percentage reported as inhibition, at one concentration (the size of the read-out at that concentration, not a potency): 59.5%
Estimate against measurement, compound 3: 20.5 percentage points above; the measured number lies below the stated range.
By their numbers in this assay, from the lowest: compound 3; then compounds 1 and 2 (each within the scatter of the next).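

In this assay, among the compounds shown here, putting 5-fluoro-2-methoxyphenyl in place of 3-ethylphenyl on a nitrogen on an aromatic ring gives a number 22.6 percentage points lower from compound 1 to compound 3 (beyond the scatter), the first step between measured compounds that differ in one place. It shows that the read-out responds to the choice of ring at this position, even with the rest of the structure held constant and an aromatic carbon ring on both sides of the change. Nothing available accounts for the size or direction of this step.

The fluorine and the methoxy group enter together, so the compounds shown leave open how much of the step belongs to each. Also open, from the compounds shown here alone, is whether a dimethylamino group or a longer chain such as propyl on this ring would hold the number near that of compound 1.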